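From compound 2 to compound 3: chloro for methoxy

The source may hold more compounds than are shown below. What is called first, only, known or untested is meant among the compounds shown, and "the series" means these compounds.

In an ADME assay on HepG2 cells (Homo sapiens) for cytotoxicity, with a stated time of 72 h (a lower number here means that less compound is needed, a higher number that more compound is needed for the effect), compound 1 (`Cc1cc(NC(=O)Nc2cccc([N+](=O)[O-])c2)c2ccccc2n1`) gives > 25000 nM as a limit of the assay. Compound 2 (`COc1cccc(NC(=O)Nc2cc(C)nc3ccccc23)c1`) gives > 25000 nM as a limit too, so it stands without a number. Both results sit together (the limit of > 25000 nM in this assay, at which 2 of the 2 values shown sit). For the measured compounds named here, the only measured step (a step that the two limits leave unreadable from compound 1 to compound 2) offers no size to carry forward. Compound 3 (`Cc1cc(NC(=O)Nc2cccc(Cl)c2)c2ccccc2n1`) has chloro in place of methoxy on an aromatic carbon. No step beyond the scatter and no direction is expected (a step that the limit leaves unreadable from compound 2 to compound 3). Compound 3 is estimated at 30000 nM (12000 nM to 60000 nM), with another limit the likeliest report.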

Compound 3, half-maximal effective concentration: 19000 nM
Compound 3: the middle estimate sits 1.6-fold (0.20 log units) above what was measured, within the range that was stated.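

For the compounds shown here, compound 3 is the first in this set to give a number rather than a limit in this assay, with chloro on an aromatic carbon, meta to a large group. Chloro in place of methoxy gives an at least 1.3-fold lower number from compound 2 to compound 3 (0.11 log units; that floor lies within the scatter), and chloro in place of nitro gives an at least 1.3-fold lower number from compound 1 to compound 3 (0.11 log units; that floor lies within the scatter). Both floors lie within the scatter, so no order among the three groups can be drawn, and the limit remains the commonest result: the limit of > 25000 nM in this assay, at which 2 of the 3 values shown sit.

Still open, going by these compounds, is whether an amine or a carboxylic acid in this place would give a number, and whether any such step would clearly exceed the scatter.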